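Fluoro on the pyridine of compound 2

This account rests on a few compounds, and the source may have more. Where it says the series, first, only, none or still open, it means among the compounds named here.

Of the compounds shown here, three define the series so far in a functional assay on MDA-MB-231 cells (Homo sapiens) for cytotoxicity, read by MTT assay, with a stated time of 72 h; on this read-out higher numbers stand for weaker inhibition and lower numbers for stronger inhibition. For compound 1 `Nc1ccccc1NC(=O)c1ccc(NC(=S)NCc2cccnc2)cc1` the entry reads "not determined" (no result reported). Compound 2 `Nc1ccccc1NC(=O)c1ccc(NC(=O)NCc2cccnc2)cc1` gives > 100000 nM, which is a limit of the assay and not a number. Going by the values given here, compound 3 `Nc1ccccc1NC(=O)c1ccc(NC(=O)/C(Cl)=C(\Cl)c2cccnc2)cc1` gives 13000 nM, the only single number available. The position of compound 2 is therefore known only as the limit of > 100000 nM in this assay, at which 1 of the 3 values shown sits.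

Compound 4 `Nc1ccccc1NC(=O)c1ccc(NC(=O)NCc2ccc(F)nc2)cc1` is the next to be read. It carries fluoro in place of hydrogen on an aromatic carbon, next to the ring nitrogen and para to a large group, turning pyridin-3-yl into 6-fluoropyridin-3-yl (fluoro in place of hydrogen on an aromatic carbon). Among the compounds with values here, no measured pair differs in one place only, so the data offer no direct precedent for this change.

The expectation starts from compound 2 and its limit of > 100000 nM. Expected here is a number no higher from compound 2 to compound 4 (the limit leaves the size open), with no step beyond the usual scatter and no preferred direction. Another report as a limit in this assay is considered the more likely outcome. For compound 4 the estimated value is 100000 nM, with an expected range of 40000 nM to 250000 nM.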

Compound 4, half-maximal inhibitory concentration: 91000 nM
For compound 4 the middle estimate is 1.1-fold (0.04 log units) above the measured one; the range from low to high includes it.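

In this assay compound 4 gives a single number, 91000 nM, so a compound carrying the (6-fluoropyridin-3-yl)methyl group has a value of its own. Compound 2, the pyridin-3-yl parent, offers only a limit. Fluoro in place of hydrogen on this aromatic carbon, next to the ring nitrogen and para to a large group, gives an at least 1.0-fold lower number from compound 2 to compound 4 (0.04 log units; that floor lies within the scatter), so the printed floor of the step shows no change beyond the scatter. As far as these compounds go, the real size of the step stays unknown because compound 2 is reported only as a limit and not as a number: the limit of > 100000 nM in this assay, at which 1 of the 4 values shown sits.

From the compounds shown here alone, it remains open whether the step from hydrogen to fluoro is larger than this floor, and whether a chloro, methoxy or amino group on the same aromatic carbon would read like fluoro. Also open, going by these compounds, is whether fluoro has any comparable step in the compounds with the thiourea link of compound 1 or the dichloroalkene link of compound 3, since neither has a one-place partner here.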